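Fluoro in place of methyl on a pyridin-2-yl group

The source may report more compounds than this note shows. Statements on the series, on what has been measured and on what is new or still open speak of the compounds shown alone.

In an ADME assay on microsomes from liver (Mus musculus) for metabolic stability, read by LC-MS, using NADPH, with a stated time of 10 min, tested at 0.1 uM (on this read-out lower numbers stand for slow clearance and higher numbers for fast clearance), compound 1 `COc1ccc(F)cc1N1C(=O)CSC1c1cccc(C(=O)NCCCCn2cccn2)c1` gives 1310 mL.min-1.g-1 with 5-fluoro-2-methoxyphenyl on the amide-type nitrogen in the ring. Compound 2 `O=C(NCCCCn1cccn1)c1cccc(C2SCC(=O)N2c2ccccn2)c1` gives 304 mL.min-1.g-1 with pyridin-2-yl there, and compound 3 `Cc1ccnc(N2C(=O)CSC2c2cccc(C(=O)NCCCCn3cccn3)c2)c1` gives 392 mL.min-1.g-1 with 4-methylpyridin-2-yl. Compound 3 therefore stands in the pair with the lower numbers: the data show a 1.3-fold higher number from compound 2 to compound 3 (0.11 log units; within the scatter) but also a 3.3-fold lower number from compound 1 to compound 3 (0.52 log units; beyond the scatter) on the same scale. Compound 4 `O=C(NCCCCn1cccn1)c1cccc(C2SCC(=O)N2c2cc(F)ccn2)c1` comes from compound 3 by a single change (fluoro in place of methyl on an aromatic carbon), fluoro in place of methyl on an aromatic carbon, opposite the ring nitrogen. Among the measured compounds shown here, no measured pair makes this exact swap. The closest evidence is the methyl-for-hydrogen step at the same carbon, already shown to lie within the scatter. The exchange of the whole group, a 4.3-fold lower number from compound 1 to compound 2 (0.63 log units; beyond the scatter) as the example, is a different kind of change and offers little guidance. No step beyond the scatter is therefore expected (expected step: a 1.3-fold lower number from compound 3 to compound 4 (0.12 log units; within the scatter)). For compound 4 the estimate is 300 mL.min-1.g-1 as a middle value, with 170 mL.min-1.g-1 to 530 mL.min-1.g-1 as the expected range.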

Compound 4, intrinsic clearance in microsomes: 397 mL.min-1.g-1
The estimate for compound 4 lay 1.3-fold (0.12 log units) below the measured number; the range from low to high includes it.
By their numbers in this assay, from the lowest: compounds 2, 3 and 4 (each within the scatter of the next); then compound 1.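

In this assay the carbon opposite the ring nitrogen has now carried hydrogen, methyl and fluoro with no separation among them: fluoro for methyl gives no step beyond the scatter (a 1.0-fold higher number from compound 3 to compound 4 (0.01 log units; within the scatter)), and neither does fluoro for hydrogen (a 1.3-fold higher number from compound 2 to compound 4 (0.12 log units; within the scatter)). The 4-fluoropyridin-2-yl group also keeps the gap from the 5-fluoro-2-methoxyphenyl group (a 3.3-fold lower number from compound 1 to compound 4 (0.52 log units; beyond the scatter)), so among these compounds only compound 1 stands apart. Nothing measured here accounts for these three substituents reading alike.

On these data alone, whether an amine, a carboxylic acid or a longer chain at this same carbon would also read like hydrogen, methyl and fluoro stays open. So does whether fluoro would read the same on the other carbons of the pyridin-2-yl group.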